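Removing the ring hydroxy from a compound with a low paw-edema number

A few compounds are considered here, and "the series" means these few. Any claim that something is new, unique, unknown or untested is made for them only; others in the source may bear on it.

Measured compounds:
compound 1 `Cc1ccc(S(=O)(=O)N2CC(O)C[C@H]2C(=O)Nc2ccc(C(=O)O)cc2)cc1`: 84%
compound 2 `O=C(O)c1ccc(NC(=O)[C@@H]2CC(O)CN2S(=O)(=O)c2ccccc2)cc1`: 1.85%

Compound 1 has the higher number of the two in a functional assay on the whole organism for inhibition, with Rattus norvegicus as the target, read by paw edema, with stated times of 1 h and 3 h, at a dose of 100 mg/kg by the oral route (on this read-out higher numbers stand for more inhibition at the one dose given (going by the name of the read-out) and lower numbers for less inhibition), and compound 2 stands lowest of the two numbers shown, with a number 82.2 percentage points lower from compound 1 to compound 2 (beyond the scatter) separating them. The next compound, compound 3 `O=C(O)c1ccc(NC(=O)[C@@H]2CCCN2S(=O)(=O)c2ccccc2)cc1`, differs from compound 2 by hydrogen in place of hydroxy on a saturated ring carbon. Going by the values given here, the only measured step concerns a different change, methyl to hydrogen on an aromatic carbon, and it was large, so it shows that this series can swing widely but says nothing direct about the hydroxy. Among the compounds with values here, with no matching precedent, the expectation for compound 3 is kept near the low value of compound 2 with wide uncertainty. Compound 3 is therefore expected to reach about 15%, within 0% to 45%. This estimate corresponds to an expected step of a number 13.2 percentage points higher from compound 2 to compound 3 (beyond the scatter).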

Compound 3, a percentage reported as inhibition, in the whole organism at one dose (the size of the read-out at that dose, not a potency): 31.2%
For compound 3 the middle estimate is 16.2 percentage points below the measured one; measured number inside the range.
By their numbers in this assay, from the lowest: compound 2; then compound 3; then compound 1.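

Taking the hydroxy off this saturated ring carbon, two ring bonds from the ring nitrogen, gives in this assay (a number 29.4 percentage points higher from compound 2 to compound 3 (beyond the scatter)) the first direct reading of this position. The hydroxy is therefore not required for the compound to register inhibition at this dose, and its removal raises the number by a modest amount that still lies beyond the usual scatter. This rests on one pair of compounds, and nothing available explains why the number rises.

From the compounds shown here alone, it remains open whether the same change would act alike on the core of compound 1, which carries the aromatic methyl. Going by these compounds, it also remains open how this ring carbon would respond to a different group there, such as an amine or a methoxy.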